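This account rests on a few compounds, and the source may have more. Where it says the series, first, only, none or still open, it means among the compounds named here.

Going by the values given here, compound 1 `CC(C)/C(=C(/c1ccc(/C=C/C(=O)O)cc1)c1ccc2[nH]ncc2c1)c1ccccc1` and compound 2 `CC/C(=C(/c1ccc(/C=C/C(=O)O)cc1)c1cc2cn[nH]c2cc1C)c1ccccc1` share a core but differ in several places at once, so no single step joins them. In a functional assay on MCF7 cells (Homo sapiens) for cytotoxicity, read by CellTiter-Glo, with a stated time of 5 days (on this read-out higher numbers stand for weaker inhibition and lower numbers for stronger inhibition), compound 1 gives 4 nM, while compound 2 gives 468 nM, the higher of the two numbers shown, and the gap between them lies beyond the scatter. Compound 3 `CC/C(=C(/c1ccc(/C=C/C(=O)O)cc1)c1cc2cn[nH]c2cc1Cl)c1ccccc1` differs from compound 2 in one place: chloro in place of methyl on an aromatic carbon. Among the compounds with values here, no measured step of this kind exists, so the change from compound 2 to compound 3 is expected to stay within the scatter, a 1.2-fold lower number from compound 2 to compound 3 (0.07 log units; within the scatter). Compound 3 is therefore estimated at 400 nM in this assay, within 100 nM to 1500 nM.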

Compound 3, half-maximal inhibitory concentration: 137 nM
Compound 3: middle estimate off by 2.9-fold (0.47 log units), on the high side; measured number inside the range.
By their numbers in this assay, from the lowest: compound 1; then compound 3; then compound 2.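

In this assay, replacing methyl with chloro on this aromatic carbon gives a 3.4-fold lower number from compound 2 to compound 3 (0.53 log units; beyond the scatter), a modest step. The change from 6-methyl-1H-indazol-5-yl to 6-chloro-1H-indazol-5-yl involves one heavy atom for one heavy atom, so this position responds to even a small swap. No measurement shown here explains the shift.

The compounds shown leave open how fluoro, methoxy or an amine would read at this position. They also leave open whether the step from methyl to chloro would hold with the isopropyl-bearing core of compound 1.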